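Swapping trifluoromethyl for methoxy on a fused bicyclic core

The source may report more compounds than this note shows. Statements on the series, on what has been measured and on what is new or still open speak of the compounds shown alone.

This small series rests on a shared core carrying a 3-pentyl chain, seen in compound 1 `CCC(CC)n1c(=O)[nH]c2nccnc21`. In an ADME assay on microsomes from liver (Homo sapiens), read by LC-MS, with a stated time of 90 min (on this read-out higher numbers stand for higher hepatic extraction and lower numbers for lower hepatic extraction), compound 1 gives "not determined" (no result reported), so no number is available for it. Compound 2 `CCC(CC)n1c(=O)[nH]c2ncc(C(F)(F)F)nc21` carries a trifluoromethyl group on the six-membered aromatic ring of that core. In this assay compound 2 gives only a limit of the assay, < 0.2, and not a number. This is the situation described by the limit of < 0.2 in this assay, at which 1 of the 2 values shown sits, so on the numbers shown compound 2 sits at the low edge of what the assay reports, with compound 1 offering no point of comparison. Compound 3 `CCC(CC)n1c(=O)[nH]c2ncc(OC)nc21` differs from compound 2 in one place: methoxy in place of trifluoromethyl on an aromatic carbon. Going by the values given here, no measured pair in this set shows what such a change does in this assay, so the expectation rests on the change alone. In this assay the step from compound 2 to compound 3 is expected to be a number at least 0.15 higher from compound 2 to compound 3 (beyond the scatter), upward and larger than the usual scatter. Compound 3 is therefore estimated at 0.35, within 0.1 to 0.6.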

Compound 3, hepatic extraction ratio: < 0.2
Compound 3 was reported as a limit; the forecaster's own chance of this, stated with the estimate: 30%; middle value at least 0.15 from the limit.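

Compound 2 and compound 3 are both reported only as a limit of this assay, not as a number: the limit of < 0.2 in this assay, at which 2 of the 3 values shown sit. Going by these compounds alone, no step from one to the other can therefore be read. The compounds shown leave open where the hepatic extraction of each truly lies, and so whether methoxy in place of trifluoromethyl changes it at all.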